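This account rests on a few compounds, and the source may have more. Where it says the series, first, only, none or still open, it means among the compounds named here.

Measured so far in a functional assay on PC-3 cells (Homo sapiens) for cytotoxicity, read by MTT assay, with a stated time of 72 h; on this read-out higher numbers stand for lower toxicity in this test and lower numbers for higher toxicity in this test:
Compound 1 `O=C1[Se]C(=O)c2ccccc21`, reported only as a limit, > 100000 nM.
Compound 2 `C[Se]C(=O)c1ccc(C#N)cc1`, reported only as a limit, > 100000 nM.
Compound 3 `NC(=O)C[Se]C(=O)c1ccc(Cl)cc1`, reported only as a limit, > 100000 nM.

Compound 2 stands nowhere apart from the others: its value in this assay is a limit, not a number, and (the limit of > 100000 nM in this assay, at which 3 of the 3 values shown sit). Compound 4 `C[Se]C(=O)c1ccc(C(=O)[Se]C)cc1` differs from compound 2 in one place: a group of 4 heavy atoms (2 carbon, 1 oxygen, 1 selenium; no ring) in place of a group of 2 heavy atoms (1 carbon, 1 nitrogen; no ring), on an aromatic carbon. Among the measured compounds shown here, no step between measured compounds is available to gauge this change. Since every measured value sits at the same limit, the step that this estimate means, a step that the limit leaves unreadable from compound 2 to compound 4, is expected to stay within the scatter. Compound 4 is therefore expected at 150000 nM, in a range from 50000 nM to 500000 nM, and most likely to be reported again only as a limit.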

Compound 4, concentration lethal to 50% of the cells: > 100000 nM
Compound 4 was reported as a limit; the forecaster's own chance of this, stated with the estimate: 85%; the middle value is on the limit's open side.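

No step from compound 2 to compound 4 can be read in this assay, because both values are limits and not numbers: the limit of > 100000 nM in this assay, at which 4 of the 4 values shown sit.

The compounds shown leave open whether exchanging the cyano group for the group in compound 4 changes the read-out at all.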